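Quinazoline-type series: difluoromethyl shift toward the pyridyl analogue

A few compounds are considered here, and "the series" means these few. Any claim that something is new, unique, unknown or untested is made for them only; others in the source may bear on it.

Measured so far:
compound 1 `Cc1ccc(CNc2nc(-c3ccccc3C(F)(F)F)nc3ccccc23)s1` — 5100 nM
compound 2 `FC(F)(F)c1ccccc1-c1nc(NCc2ccc(-c3ccc(Cl)c(Cl)c3)cc2)c2ccccc2n1` — 2200 nM
compound 3 `FC(F)(F)c1ccc(-c2nc(NCc3ccc(-c4cccnc4)cc3)c3ccccc3n2)cc1` — "not active" (no number reported), no number

In an assay on a protein complex for inhibition of ubiquitin carboxyl-terminal hydrolase 1/WD repeat-containing protein 48 (Homo sapiens), read by fluorescence (a lower number here means a stronger inhibitor, a higher number a weaker inhibitor), compound 1 gives 5100 nM and compound 2 gives 2200 nM; both carry a trifluoromethyl group on the aryl ring attached to the shared core. Compound 3 is reported as "not active" (no number reported) in this assay, so it stands with no number at all, below anything the two measured values can be compared to. Compound 4 `FC(F)c1ccccc1-c1nc(NCc2ccc(-c3cccnc3)cc2)c2ccccc2n1` differs from compound 3 in one place: 2-(difluoromethyl)phenyl in place of 4-(trifluoromethyl)phenyl on an aromatic carbon. Among the measured compounds shown here, with no measured step for this change, only compound 3's inactivity and the values of compound 1 and compound 2 guide the guess; some recovery of inhibition is expected, of uncertain size. For compound 4 the estimate in this assay is 4500 nM, between 1000 nM and 20000 nM.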

Compound 4, half-maximal inhibitory concentration: 1400 nM
Beside the measured number, compound 4's estimate is 3.2-fold (0.51 log units) above it, within the range that was stated.
By their numbers in this assay, from the lowest: compounds 4 and 2 (each within the scatter of the next); then compound 1.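

Among the compounds shown here, compound 3 has no number in this assay, so no step to compound 4, at 1400 nM, can be read. The compounds shown leave open how the group's substitution position and its fluorine count each contribute, and no supporting data bear on this.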